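From fluoro to methoxycarbonyl on the shared core

The compounds below may be only part of what the source reports. "The series", "measured", "known", "first", "only" and "open" are said of these compounds alone.

Measured in a physicochemical assay for solubility, at pH 7.4; a higher number here means a more soluble compound, a lower number a less soluble compound:
- compound 1 `CSc1ccc(NC(=O)Nc2cc(C)nc3ccccc23)cc1`: 1300 nM
- compound 2 `CC(=O)c1ccc(NC(=O)Nc2cc(C)nc3ccccc23)cc1`: 3800 nM
- compound 3 `Cc1cc(NC(=O)Nc2ccc(F)cc2)c2ccccc2n1`: 3700 nM

Compound 3, at 3700 nM, stands level with compound 2 within the scatter, and both lie beyond the scatter from compound 1. Compound 4 `COC(=O)c1ccc(NC(=O)Nc2cc(C)nc3ccccc23)cc1` carries methoxycarbonyl in place of fluoro on an aromatic carbon, para to a large group: methoxycarbonyl in place of fluoro on an aromatic carbon. Going by the values given here, no measured step makes this exact change. The nearest evidence is the acetyl of compound 2, which like methoxycarbonyl holds a carbonyl. The exchange with fluoro there gave a 1.0-fold lower number from compound 2 to compound 3 (0.01 log units; within the scatter). Methylsulfanyl is the only group that has moved the number, in a 2.9-fold higher number from compound 1 to compound 2 (0.47 log units; beyond the scatter) and a 2.8-fold higher number from compound 1 to compound 3 (0.45 log units; beyond the scatter). Neither of those steps involves the exchange at hand, so no step beyond the scatter is expected in this assay. The expected change is a 1.2-fold lower number from compound 3 to compound 4 (0.09 log units; within the scatter). Compound 4 is estimated at 3000 nM, with an expected range of 1300 nM to 6000 nM.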

Compound 4, solubility: 1200 nM
The estimate for compound 4 lay 2.5-fold (0.40 log units) above the measured number; measured number below the stated range.
By their numbers in this assay, from the lowest: compounds 4 and 1 (each within the scatter of the next); then compounds 3 and 2 (each within the scatter of the next).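

At this position on the shared core, holding a carbonyl did not make two groups equivalent in this assay: fluoro to methoxycarbonyl gave a 3.1-fold lower number from compound 3 to compound 4 (0.49 log units; beyond the scatter), and methoxy in place of methyl on the carbonyl carbon gave a 3.2-fold lower number from compound 2 to compound 4 (0.50 log units; beyond the scatter), so acetyl proved a poor stand-in for methoxycarbonyl. Methylsulfanyl also no longer stands alone at the low end of the series, since methoxycarbonyl in its place gave a 1.1-fold lower number from compound 1 to compound 4 (0.03 log units; within the scatter) and the two groups cannot be told apart here. Nothing available bears on the reason for the difference between acetyl and methoxycarbonyl.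

As far as these compounds go, whether a primary amide or a carboxylic acid at this place would read like acetyl or like methoxycarbonyl remains open. So does whether ethoxycarbonyl, with its longer chain, would stay level with methoxycarbonyl.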